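From 3-bromophenyl to 3-fluorophenyl in the series

The compounds below may be only part of what the source reports. "The series", "measured", "known", "first", "only" and "open" are said of these compounds alone.

In a functional assay on DU-145 cells (Homo sapiens) for antiproliferative activity, read by MTT assay, with a stated time of 48 h (on this read-out lower numbers stand for stronger inhibition and higher numbers for weaker inhibition), compound 1 `C/C(=C\CC/C(C)=C/CC[C@@H]1[C@@]2(C)CCC(=O)C(C)(C)[C@H]2CC[C@@]1(C)O)CC/C=C(\C)C(=O)OCc1cn(-c2cccc(C)c2)nn1` gives 137000 nM as its reading. Compound 2 `C/C(=C\CC/C(C)=C/CC[C@@H]1[C@@]2(C)CCC(=O)C(C)(C)[C@H]2CC[C@@]1(C)O)CC/C=C(\C)C(=O)OCc1cn(-c2cccc(Br)c2)nn1` returns > 150000 nM as its reading, which is a limit of the assay and not a number. Its standing is therefore only the limit of > 150000 nM in this assay, at which 1 of the 2 values shown sits, and no exact place on the scale can be given.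

Compound 3 `C/C(=C\CC/C(C)=C/CC[C@@H]1[C@@]2(C)CCC(=O)C(C)(C)[C@H]2CC[C@@]1(C)O)CC/C=C(\C)C(=O)OCc1cn(-c2cccc(F)c2)nn1` carries fluoro in place of bromo on an aromatic carbon and keeps the shared core. The site is on a six-membered aromatic ring of carbon only, meta to a large group.

Within the data shown here, the one measured step at this site is bromo in place of methyl, which gave an at least 1.0-fold higher number from compound 1 to compound 2 (0.03 log units; that floor lies within the scatter) as its outcome. That step is only a floor, so it shows no shift beyond the scatter and sets no bound on a larger one.

Among the measured compounds shown here, compound 1 with 137000 nM is the only numbered neighbour, so a reading in the same region is expected. The expected change is an at least 1.2-fold lower number from compound 2 to compound 3 (0.07 log units; that floor lies within the scatter) and it is not expected to pass the scatter. For compound 3 the estimate is 125000 nM with an expected range of 65000 nM to 170000 nM in this assay as the read-out.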

Compound 3, half-maximal inhibitory concentration: > 150000 nM
Compound 3 gave a limit, no number; the forecaster's own chance of this, stated with the estimate: 45%; middle value at least 1.2-fold (0.07 log units) away from the limit.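

With fluoro on this aromatic carbon, this assay again ends in a limit of the assay and not a number, so compound 2 and compound 3, with two different halogens at the site, now stand at the same limit: the limit of > 150000 nM in this assay, at which 2 of the 3 values shown sit.

Fluoro in place of methyl gives an at least 1.0-fold higher number from compound 1 to compound 3 (0.03 log units; that floor lies within the scatter), so this second change away from methyl also shows no shift beyond the scatter and sets no bound on a larger one. Compound 1, with its methyl, gives 137000 nM and remains the only exact number among the compounds shown, while the step between compound 2 and compound 3 cannot be read.

Still open, going by these compounds, is how far compound 2 and compound 3 lie from compound 1, and whether either halogen differs from the other in this read-out at all. Also open, on these data alone, is whether any other group on this aromatic carbon, such as an amine, a carboxylic acid or a methoxy, would give a reading clearly lower than that of compound 1.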